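Halogen exchange on the benzyl group of the triazole series

The source may hold more compounds than are shown below. What is called first, only, known or untested is meant among the compounds shown, and "the series" means these compounds.

Compound 1 `Cc1cccc(Cn2cc(COc3ccc4c(=O)ccoc4c3)nn2)c1` gives 16000 nM in a functional assay on MDA-MB-231 cells (Homo sapiens) for cytotoxicity, read by MTT assay, with a stated time of 48 h; on this read-out higher numbers stand for weaker inhibition and lower numbers for stronger inhibition. For compound 2 `O=c1ccoc2cc(OCc3cn(Cc4ccc(Br)cc4)nn3)ccc12` this assay reports only a limit, > 100000 nM. Compound 3 `O=c1ccoc2cc(OCc3cn(Cc4ccccc4Cl)nn3)ccc12` gives 15100 nM in this assay, the lowest of the two numbers shown; its nearest neighbour is compound 1, and the step of a 1.1-fold lower number from compound 1 to compound 3 (0.03 log units; within the scatter) lies within the scatter. The other step onto compound 3, an at least 6.6-fold lower number from compound 2 to compound 3 (0.82 log units; beyond the scatter), is beyond the scatter, but it starts from a limit.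

Compound 4 `O=c1ccoc2cc(OCc3cn(Cc4ccccc4F)nn3)ccc12` differs from compound 3 by fluoro in place of chloro on an aromatic carbon. For the measured compounds named here, no measured step exchanges one halogen for another at the same place; the steps that bear on it are the two into compound 3. Compound 1 and compound 3 sit together, and the large step involved 4-bromophenyl rather than a change of halogen on the 2-substituted ring. Compound 4 is therefore expected to show no step beyond the scatter, a 1.0-fold lower number from compound 3 to compound 4 (0.00 log units; within the scatter). Compound 4 is estimated at 15000 nM, with a range from 6000 nM to 40000 nM.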

Compound 4, half-maximal inhibitory concentration: 29800 nM
For compound 4 the middle estimate is 2.0-fold (0.30 log units) below the measured one; low and high end bracket the measured number.
By their numbers in this assay, from the lowest: compounds 3, 1 and 4 (each within the scatter of the next). At a limit, above all of these: compound 2.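

For the compounds shown here, the first exchange of one halogen for another at the same place, a 2.0-fold higher number from compound 3 to compound 4 (0.30 log units; within the scatter), stays within the scatter in this assay, on an aromatic carbon ortho to a large group. With a 1.9-fold higher number from compound 1 to compound 4 (0.27 log units; within the scatter) also within the scatter, 2-fluorophenyl joins 2-chlorophenyl and 3-methylphenyl as groups that this read-out does not separate. The only new step beyond the scatter, an at least 3.3-fold lower number from compound 2 to compound 4 (0.52 log units; beyond the scatter), starts from a limit and again involves 4-bromophenyl: the limit of > 100000 nM in this assay, at which 1 of the 4 values shown sits.

Open, going by these compounds, is whether the step to compound 2 goes with bromo or with its place on the ring, a question that 2-bromophenyl and 4-fluorophenyl would separate. Also open, on these data alone, is how a group of another kind on the ring, such as an amine or a carboxylic acid, would read in this assay.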